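A few compounds are considered here, and "the series" means these few. Any claim that something is new, unique, unknown or untested is made for them only; others in the source may bear on it.

Compound 1 `COc1ccc(-c2cc(/C=C/C(=O)c3ccc(N)cc3)[nH]n2)cc1`: -2%
Compound 2 `COc1cc(-c2cc(/C=C/C(=O)c3ccc(N)cc3)[nH]n2)cc(OC)c1OC`: -32%

In a functional assay on NCI-H322M cells (Homo sapiens) for cytotoxicity, read by sulforhodamine B assay, with a stated time of 48 h, tested at 10 uM (on this read-out higher numbers stand for a weaker effect at the one concentration tested and lower numbers for a stronger effect), compound 2 stands lowest of the two numbers; compound 1 gives -2%, a number higher by a gap beyond the usual scatter. Compound 3 `COc1ccc(-c2cc(/C=C/C(=O)c3ccc(N)cc3)[nH]n2)cc1OC` differs from compound 2 by hydrogen in place of methoxy on an aromatic carbon. Among the measured compounds shown here, no measured pair shows this change, so its effect is unknown. Compound 3 is expected to move upward from compound 2 by a step of a number 15 percentage points higher from compound 2 to compound 3 (beyond the scatter), modest and perhaps not beyond the scatter. Compound 3 is therefore estimated at -17%, with a range from -38% to 4%.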

Compound 3, a percentage reported as activity, at one concentration (the size of the read-out at that concentration, not a potency): 24%
Estimate against measurement, compound 3: 41 percentage points below; measured number outside the range, above it.
By their numbers in this assay, from the lowest: compound 2; then compound 1; then compound 3.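

In this assay the loss of this methoxy gives a number 56 percentage points higher from compound 2 to compound 3 (beyond the scatter) and so a much weaker effect, while the gain of a methoxy on the core of compound 1 gives a number 26 percentage points higher from compound 1 to compound 3 (beyond the scatter) and also weakens the effect. Methoxy in place of hydrogen on an aromatic carbon therefore has no single direction here: it weakens the effect on the way to compound 3 and strengthens it on the way to compound 2. Nothing available explains this reversal.

From the compounds shown here alone, whether the strong effect of compound 2 depends on methoxy itself at this position remains open. A hydroxy group, a fluorine atom or an ethoxy chain there could settle that.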